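Chloro for Methoxy on the Shorter Linker

The compounds below may be only part of what the source reports. "The series", "measured", "known", "first", "only" and "open" are said of these compounds alone.

Of the compounds shown here, three have been measured. Compound 1, `COc1ccccc1N1CCN(CCCn2ncc(N3CCN(C(=O)c4ccco4)CC3)c(Cl)c2=O)CC1`, in an assay on cell membranes for binding affinity to Adrenergic receptor alpha-1 (Rattus norvegicus), read by radioligand binding (a higher number here means a weaker inhibitor, a lower number a stronger inhibitor), gives 20.4 nM. Compound 2, `O=C(c1ccco1)N1CCN(c2cnn(CCCN3CCN(c4ccccc4Cl)CC3)c(=O)c2Cl)CC1`, in this assay gives 3.5 nM. Compound 3, `COc1ccccc1N1CCN(CCn2ncc(N3CCN(C(=O)c4ccco4)CC3)c(Cl)c2=O)CC1`, in this assay gives 33 nM.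

Compound 3 has the highest of the three numbers. Its nearest neighbour is compound 1, and the two lie within the scatter of each other; compound 2 lies far from it, beyond the scatter, and is the strongest of the three.

Compound 4, `O=C(c1ccco1)N1CCN(c2cnn(CCN3CCN(c4ccccc4Cl)CC3)c(=O)c2Cl)CC1`, has not yet been measured in this assay. It differs from compound 3 in one place: chloro in place of methoxy on an aromatic carbon. The same change has already been made once, on the compounds with the longer chain, and there it gave a 5.8-fold lower number from compound 1 to compound 2 (0.77 log units; beyond the scatter). That step is the only one that bears here, and it lies beyond the scatter, so a step of similar size and direction is expected: a 5.5-fold lower number from compound 3 to compound 4 (0.74 log units; beyond the scatter). Compound 4 is therefore estimated at 6 nM, within a range from 2.5 nM to 15 nM.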

Compound 4, inhibition constant: 3.9 nM
For compound 4 the middle estimate is 1.5-fold (0.19 log units) above the measured one; the range from low to high includes it.
By their numbers in this assay, from the lowest: compounds 2 and 4 (each within the scatter of the next); then compounds 1 and 3 (each within the scatter of the next).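

On the shorter chain, the change from 2-methoxyphenyl to 2-chlorophenyl gives an 8.5-fold lower number from compound 3 to compound 4 (0.93 log units; beyond the scatter) in this assay, so the change at this position no longer rests on the longer chain alone. Its effect on the number is of similar size on both chain lengths: the same change on two cores in this assay, a 5.8-fold lower number (0.77 log units; beyond the scatter) from compound 1 to compound 2 and an 8.5-fold lower number (0.93 log units; beyond the scatter) from compound 3 to compound 4, 1.5-fold (0.16 log units) apart, within the scatter of two such steps. With chloro at this position, chain length leaves the values within the scatter of each other, with compound 2 at 3.5 nM and compound 4 at 3.9 nM.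

The compounds shown leave open whether fluoro, methyl or trifluoromethyl at this position would give a similar step, and whether chloro elsewhere on the same ring would do so. They also leave open how a butyl chain, longer than either chain here, would read in this assay.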